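From propyl to 2-(dimethylamino)ethyl on the shared core

The compounds below may be only part of what the source reports. "The series", "measured", "known", "first", "only" and "open" are said of these compounds alone.

In a functional assay on TSGH cells (Homo sapiens) for inhibition, with a stated time of 72 h (a higher number here means a weaker inhibitor, a lower number a stronger inhibitor), compound 1 `COc1cc(C(=O)c2cccc3[nH]ccc23)cc(OC)c1OC` gives 54.4 nM as its value, while compound 2 `CCCn1ccc2cc(C(=O)c3cc(OC)c(OC)c(OC)c3)ccc21` gives 1500 nM as the higher of the two numbers, a gap beyond the scatter. Compound 3 `COc1cc(C(=O)c2ccc3c(ccn3CCN(C)C)c2)cc(OC)c1OC` carries dimethylamino in place of methyl on a saturated chain carbon, two bonds along the chain from an aromatic nitrogen, so propyl becomes 2-(dimethylamino)ethyl. Among the compounds with values here, no measured step bears on this change, so only a slight move toward a lower number, within the scatter, is expected in this assay and the estimated step is a 1.5-fold lower number from compound 2 to compound 3 (0.18 log units; within the scatter) in size. Compound 3 is expected at 1000 nM with an estimated range from 250 nM to 5000 nM overall.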

Compound 3, half-maximal inhibitory concentration: 4900 nM
Estimate against measurement, compound 3: 4.9-fold (0.69 log units) below; the measured number falls inside the stated range.
By their numbers in this assay, from the lowest: compound 1; then compound 2; then compound 3.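

Dimethylamino in place of methyl on a saturated chain carbon, two bonds along the chain from an aromatic nitrogen, gives a 3.3-fold higher number from compound 2 to compound 3 (0.51 log units; beyond the scatter) in this assay. Within the data shown here, this is the first measured step at this position, and it shows that the number responds to what the chain carries, with the amine-bearing chain the weaker inhibitor of the pair. Nothing at hand gives a reason for this step. Going by these compounds, whether a hydroxyl, a carboxylic acid or a morpholine at the same chain carbon would move the number the same way remains open, as does the effect of a longer chain.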